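Tetrazole for triazole on a second core, residence time expected

The source may report more compounds than this note shows. Statements on the series, on what has been measured and on what is new or still open speak of the compounds shown alone.

Compound 1 `Cc1cc(Cl)ccc1-c1cccc(COc2ccc([C@H](CC(=O)O)c3ncnn3C)cc2)c1` and compound 2 `Cc1cc(Cl)ccc1-c1cccc(COc2ccc([C@H](CC(=O)O)c3nnnn3C)cc2)c1` share one core and differ only in that (1-methyl-1H-tetrazol-5-yl in place of 1-methyl-1H-1,2,4-triazol-5-yl on a saturated chain carbon bound to an aromatic carbon and a saturated chain carbon). In an ADME assay on the whole organism with Rattus norvegicus as the target (a lower number here means that the compound disappears faster, a higher number that the compound lasts longer), compound 1 gives 2.5 h, and compound 2 gives 5.2 h, so the change made a 2.1-fold higher number from compound 1 to compound 2 (0.32 log units; beyond the scatter). Compound 3 `Cc1nc(-c2ccc(C(F)(F)F)cc2)sc1COc1ccc([C@H](CC(=O)O)c2ncnn2C)cc1` is built on a different core; the difference between the two cores is not broken down here. In this assay compound 3 gives 3.6 h. Compound 4 `Cc1nc(-c2ccc(C(F)(F)F)cc2)sc1COc1ccc([C@H](CC(=O)O)c2nnnn2C)cc1` has not yet been measured and stands to compound 3 as compound 2 stands to compound 1: 1-methyl-1H-tetrazol-5-yl in place of 1-methyl-1H-1,2,4-triazol-5-yl on a saturated chain carbon bound to an aromatic carbon and a saturated chain carbon. Since the earlier step was a 2.1-fold higher number from compound 1 to compound 2 (0.32 log units; beyond the scatter), a step of about the same size is expected from compound 3 to compound 4, namely a 2.0-fold higher number from compound 3 to compound 4 (0.30 log units; within the scatter), though the core of compound 3 is different. On that basis compound 4 is estimated at 7.2 h, with a likely range from 4 h to 13 h.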

Compound 4, mean residence time: 0.74 h
Compound 4: the middle estimate sits 9.7-fold (0.99 log units) above what was measured; the whole stated range lies above it.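

In this assay, putting 1-methyl-1H-tetrazol-5-yl in place of 1-methyl-1H-1,2,4-triazol-5-yl on the second core gave a 4.9-fold lower number from compound 3 to compound 4 (0.69 log units; beyond the scatter). The change therefore did not carry over between these two cores, either in direction or in size: the same change on two cores in this assay, a 2.1-fold higher number (0.32 log units; beyond the scatter) from compound 1 to compound 2 and a 4.9-fold lower number (0.69 log units; beyond the scatter) from compound 3 to compound 4, 10-fold (1.01 log units) apart, beyond the scatter of two such steps. Within the data shown here, with only two matched pairs, this shows that the outcome of the change differed with the core, but not which part of the core matters or what lies behind the reversal.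

The compounds shown leave open how the same change would behave on a third core. They also leave open how residence time would respond to a nitrile or a primary amide on that saturated chain carbon.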